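Swapping the Trimethoxyphenyl for Plain Phenyl

The compounds below may be only part of what the source reports. "The series", "measured", "known", "first", "only" and "open" are said of these compounds alone.

For the measured compounds named here, compound 1 `COc1cc(-c2nc(SCc3cn(CC(=O)NC(=O)Nc4ccccn4)nn3)nc(Nc3ccc(C)cc3)c2C#N)cc(OC)c1OC` is the only member of this small set with a definite number in a functional assay on ECa-109 cells (Homo sapiens) for inhibition, read by MTT assay, with a stated time of 72 h; a lower number here means a stronger inhibitor, a higher number a weaker inhibitor: in this assay compound 1 gives 21300 nM. Compound 2 `COc1cc(-c2nc(SCc3cn(CC(=O)NC(=O)Nc4ccccn4)nn3)nc(Nc3cccc(C(F)(F)F)c3)c2C#N)cc(OC)c1OC` reaches only the limit of the assay, > 64000 nM. Compound 3 `COc1cc(-c2nc(SCc3cn(CC(=O)NC(=O)Nc4ccccn4)nn3)nc(Nc3ccc(Cl)cc3)c2C#N)cc(OC)c1OC` likewise stops at the limit, > 64000 nM. Both the step of an at least 3.0-fold higher number from compound 1 to compound 2 (0.47 log units; beyond the scatter) and the step of an at least 3.0-fold higher number from compound 1 to compound 3 (0.47 log units; beyond the scatter) therefore weaken inhibition, while the step that the two limits leave unreadable from compound 2 to compound 3 cannot be sized because the limit of > 64000 nM in this assay, at which 2 of the 3 values shown sit, hides any difference between them.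

Compound 4 `Cc1ccc(Nc2nc(SCc3cn(CC(=O)NC(=O)Nc4ccccn4)nn3)nc(-c3ccccc3)c2C#N)cc1` changes a different part of the molecule: phenyl in place of 3,4,5-trimethoxyphenyl on an aromatic carbon. Going by the values given here, every measured step alters the group on a nitrogen on an aromatic ring, and none touches the aryl group that is replaced here, so no measured step bears directly on this change. The 4-methylphenyl of compound 1, the only pairing with a real number, is kept. With no direct guide, a modest weakening is expected. Compound 4 is estimated at 40000 nM. The expected range for compound 4 runs from 12000 nM to 130000 nM. That estimate corresponds to an expected step of a 1.9-fold higher number from compound 1 to compound 4 (0.27 log units; within the scatter).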

Compound 4, half-maximal inhibitory concentration: 24600 nM
For compound 4 the middle estimate is 1.6-fold (0.21 log units) above the measured one; measured number inside the range.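

Replacing 3,4,5-trimethoxyphenyl with phenyl on this aromatic carbon gives a 1.2-fold higher number from compound 1 to compound 4 (0.06 log units; within the scatter) in this assay, so the two compounds cannot be told apart. This is the first change shown at this position, and it removes 6 of the group's 12 heavy atoms and all 3 of its hydrogen-bond acceptors with no readable loss, whereas both readable changes to the group on the nitrogen weakened inhibition beyond the scatter. Nothing shown explains why this pair reads alike.

As far as these compounds go, it remains open whether this position would accept something other than a plain carbon aromatic ring, such as a pyridine ring, a morpholine amine or a carboxylic acid. Also open, from the compounds shown here alone, is whether phenyl here would behave the same alongside the 4-chlorophenyl or 3-(trifluoromethyl)phenyl groups on the nitrogen.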